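Xanthine core: tetrazolyl replaced by neopentyl

The compounds below may be only part of what the source reports. "The series", "measured", "known", "first", "only" and "open" are said of these compounds alone.

Compound 1 `CC(C)(C)CNc1ncnc2c1ncn2C1O[C@H](CO)[C@@H](O)[C@H]1O` is the reference here; in an assay on cell membranes for binding affinity to adenosine receptor A1 (Cavia porcellus), read by radioligand binding (a lower number here means a stronger inhibitor, a higher number a weaker inhibitor), compound 1 gives 17 nM. Compound 2 `CCCn1c(=O)c2nc(-c3nn[nH]n3)[nH]c2n(CCC)c1=O` carries a different core. In this assay compound 2 gives only > 10000 nM, a limit of the assay and not a number. Compound 2 therefore stands at the limit of > 10000 nM in this assay, at which 1 of the 2 values shown sits, and its gap to compound 1 cannot be sized. Compound 3 `CCCn1c(=O)c2nc(CC(C)(C)C)[nH]c2n(CCC)c1=O` differs from compound 2 by neopentyl in place of 2H-tetrazol-5-yl on an aromatic carbon. Within the data shown here, no measured pair covers this change, so no measured step can be quoted for it. Compound 2 sits at the limit; for compound 3 the expectation is a move toward measurable affinity, well beyond the scatter. The step of an at least 33-fold lower number from compound 2 to compound 3 (1.52 log units; beyond the scatter) is the expected size of that move. Compound 3 is estimated at 300 nM, within 50 nM to 3000 nM.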

Compound 3, inhibition constant: 49 nM
Compound 3: the middle estimate sits 6.1-fold (0.79 log units) above what was measured; the measured number lies below the stated range.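

With the rest of the molecule unchanged, neopentyl in place of 2H-tetrazol-5-yl, on an aromatic carbon between two ring nitrogen atoms, gives an at least 200-fold lower number from compound 2 to compound 3 (2.30 log units; beyond the scatter) in this assay. This place on the shared core therefore decides between measurable affinity and none within the assay's range, and a purely carbon group with no ring is accepted there, with compound 3 at 49 nM. The true size of the step stays unknown, as compound 2 is held at a limit of the assay and not a number: the limit of > 10000 nM in this assay, at which 1 of the 3 values shown sits.

Among these compounds, the single pair swaps ring, nitrogen atoms, donor and acceptors all at once, so it cannot say which of these differences counts. As far as these compounds go, how a carboxylic acid, a phenyl ring or a shorter chain such as ethyl would read at this place remains open.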